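The source may hold more compounds than are shown below. What is called first, only, known or untested is meant among the compounds shown, and "the series" means these compounds.

In an ADME assay on MCF-10A cells (Homo sapiens) for antiproliferative activity, read by MTT assay, with a stated time of 72 h (a higher number here means a weaker inhibitor, a lower number a stronger inhibitor), compound 1 (`CCCCSSC(=S)N(CC)CC`) gives > 10000 nM, a limit and not a number. Compound 2 (`CCN(CC)C(=S)SSCCO`) gives > 10000 nM, also a limit. Compound 3 (`CCN(CC)C(=S)SSC(C)C`) gives > 10000 nM, again a limit. Among the measured compounds shown here, the series so far therefore stands at one reading: the limit of > 10000 nM in this assay, at which 3 of the 3 values shown sit.

Compound 4 (`CCC(C)SSC(=S)N(CC)CC`) differs from compound 3 by methyl in place of hydrogen on a saturated chain carbon, two bonds along the chain from a sulfur. For the measured compounds named here, two measured steps bear on this change: a step that the two limits leave unreadable from compound 1 to compound 3 and a step that the two limits leave unreadable from compound 2 to compound 3. Neither gives a size, so no shift beyond the scatter is expected in this assay.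

The expected change is a step that the limit leaves unreadable from compound 3 to compound 4. Compound 4 is expected at 15000 nM, with an estimated range of 9000 nM to 40000 nM, and will probably again be reported as a limit.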

Compound 4, half-maximal inhibitory concentration: > 10000 nM
Compound 4: only a limit was reported; the forecaster's own chance of this, stated with the estimate: 90%; the middle value lies beyond the limit too.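

In this assay, among the compounds shown here, compound 4 gives > 10000 nM, again a limit, so no step to it from compound 1, compound 2 or compound 3 can be read. How these groups on sulfur rank against one another stays open, because all four compounds share one reading: the limit of > 10000 nM in this assay, at which 4 of the 4 values shown sit.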